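Compound 3 without its (prop-1-en-1-yl)carbonyl group

This account rests on a few compounds, and the source may have more. Where it says the series, first, only, none or still open, it means among the compounds named here.

Measured in a functional assay on HCT-116 cells (Homo sapiens) for inhibition, read by MTT assay, with a stated time of 48 h (on this read-out higher numbers stand for weaker inhibition and lower numbers for stronger inhibition), so far:
Compound 1 `COc1cc(NCc2ccc(Cl)cc2)cc(OC)c1OC` gives > 80000 nM as a limit
Compound 2 `COc1ccc(CNc2cc(OC)c(OC)c(OC)c2)cc1Br` gives 48100 nM as a number
Compound 3 `C/C=C/C(=O)N(Cc1ccc(OC)cc1)c1cc(OC)c(OC)c(OC)c1` gives 500 nM as a number

For compound 1 the entry > 80000 nM is a limit and not a number. Compound 3 stands lowest of the numbers, well beyond the usual scatter from compound 2. The change to compound 4 `COc1ccc(CNc2cc(OC)c(OC)c(OC)c2)cc1` is hydrogen in place of (prop-1-en-1-yl)carbonyl on a nitrogen on an aromatic ring and puts hydrogen in place of (prop-1-en-1-yl)carbonyl on a nitrogen on an aromatic ring. Compound 2 also carries hydrogen on that nitrogen and gives 48100 nM in this assay, so a large rise, meaning much weaker inhibition, is expected. The expected change is an 80-fold higher number from compound 3 to compound 4 (1.90 log units; beyond the scatter) and lies far beyond the scatter. For compound 4 the estimated value is 40000 nM, within an expected range from 12000 nM to 80000 nM.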

Compound 4, half-maximal inhibitory concentration: 18400 nM
Beside the measured number, compound 4's estimate is 2.2-fold (0.34 log units) above it; the range from low to high includes it.
By their numbers in this assay, from the lowest: compound 3; then compound 4; then compound 2. At a limit, above all of these: compound 1.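

In this assay, the (prop-1-en-1-yl)carbonyl group on this nitrogen matters greatly, since hydrogen in its place gives a 37-fold higher number from compound 3 to compound 4 (1.57 log units; beyond the scatter). With hydrogen on that nitrogen, changes on an aromatic carbon move the number much less: hydrogen in place of bromo gives a 2.6-fold lower number from compound 2 to compound 4 (0.42 log units; beyond the scatter). The value of compound 1 is a limit and not a number, so methoxy in place of chloro reads only as an at least 4.3-fold lower number from compound 1 to compound 4 (0.63 log units; beyond the scatter).

As far as these compounds go, it remains open whether the carbonyl alone, as in an acetyl group, would keep this inhibition, or whether the chain's double bond is also needed.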